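Extending the aminomethyl arm of compound 1

The source may report more compounds than this note shows. Statements on the series, on what has been measured and on what is new or still open speak of the compounds shown alone.

Among the measured compounds shown here, compound 1 `CCCC[S+]([O-])c1sc2nc(-c3nccs3)cc(-c3ccc(CN)cc3)c2c1N` gives 11.5 nM in an assay for inhibition of 15-hydroxyprostaglandin dehydrogenase [NAD(+)] (Homo sapiens), read by fluorescence, with a stated time of 15 min, in the presence of a further agent that is not named here (on this read-out higher numbers stand for weaker inhibition and lower numbers for stronger inhibition), the highest of the three numbers measured so far. Compound 2 `CCCC[S+]([O-])c1sc2nc(-c3nccs3)cc(-c3cnc(C)[nH]3)c2c1N` gives 2.3 nM and compound 3 `CCCC[S+]([O-])c1sc2nc(-c3nccs3)cc(-c3cccc(CO)c3)c2c1N` gives 4.3 nM. The measured steps read a 5.0-fold lower number from compound 1 to compound 2 (0.70 log units; beyond the scatter) and a 2.7-fold lower number from compound 1 to compound 3 (0.43 log units; beyond the scatter), while a 1.9-fold higher number from compound 2 to compound 3 (0.27 log units; within the scatter).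

Compound 4 `CCCC[S+]([O-])c1sc2nc(-c3nccs3)cc(-c3ccc(COC(=O)NCC)cc3)c2c1N` differs from compound 1 by (ethylcarbamoyl)oxy in place of amino on a saturated chain carbon bound to an aromatic carbon. For the measured compounds named here, no measured step bears directly on this change: each of them exchanges the whole 4-(aminomethyl)phenyl group for a different ring, so none shows what follows when the phenyl is kept and only the amino group is exchanged for the larger (ethylcarbamoyl)oxy group. The series therefore gives no footing for a direction.

Compound 4 is accordingly expected to sit close to compound 1, with the step of a 1.2-fold lower number from compound 1 to compound 4 (0.06 log units; within the scatter) expected to remain within the scatter and the range set wide to cover either direction. The estimate for compound 4 is 10 nM, between 3 nM and 40 nM.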

Compound 4, half-maximal inhibitory concentration: 3.4 nM
The estimate for compound 4 lay 2.9-fold (0.47 log units) above the measured number, within the range that was stated.
By their numbers in this assay, from the lowest: compounds 2, 4 and 3 (each within the scatter of the next); then compound 1.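

With the phenyl kept and only the amino group exchanged for (ethylcarbamoyl)oxy on a saturated chain carbon bound to an aromatic carbon, this assay gives a 3.4-fold lower number from compound 1 to compound 4 (0.53 log units; beyond the scatter). Among the compounds shown here, the earlier steps each exchanged the whole 4-(aminomethyl)phenyl group, so this is the first sign that the lower number can also be reached with that ring in place, and that the amino group can give way to a larger group on this chain carbon without the number rising. Nothing measured here accounts for the size or direction of this step.

The compounds shown leave open whether the lower number follows from the loss of the amino group or from the carbonyl and ethyl parts of the entering group. A methoxy group or a plain hydroxyl on the same chain carbon would separate these, and a propyl or butyl chain in place of the ethyl would show whether the chain can be extended further.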